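Swapping methyl for bromo on the ester-bearing ring

The source may report more compounds than this note shows. Statements on the series, on what has been measured and on what is new or still open speak of the compounds shown alone.

Measured compounds:
- compound 1, `COC(=O)c1ccc(C)cc1OC(=O)COc1cc(O)c2c(=O)cc(-c3ccccc3)oc2c1`: 31100 nM
- compound 2, `COC(=O)c1c(Br)cccc1OC(=O)COc1cc(O)c2c(=O)cc(-c3ccccc3)oc2c1`: 41700 nM

Both compounds were tested in a functional assay on cells (T-cell, Mus musculus, strain BALB/c) for inhibition, read by MTT assay, with a stated time of 72 h; on this read-out lower numbers stand for stronger inhibition and higher numbers for weaker inhibition. Compound 1 gives 31100 nM and compound 2 gives 41700 nM, and the single shown step, a 1.3-fold higher number from compound 1 to compound 2 (0.13 log units; within the scatter), is too small to rank them. Compound 1 thus stands at the lower of the two numbers, but only by a margin within the scatter.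

The unmeasured compound 3 is `COC(=O)c1ccc(Br)cc1OC(=O)COc1cc(O)c2c(=O)cc(-c3ccccc3)oc2c1`. It differs from compound 1 by bromo in place of methyl on an aromatic carbon. For the measured compounds named here, the only step that bears on this is the one from compound 1 to compound 2, where a bromo-bearing ring replaced a methyl-bearing ring, a 1.3-fold higher number from compound 1 to compound 2 (0.13 log units; within the scatter), and no movement beyond the scatter appeared. A similar outcome is expected here, with the step of a 1.1-fold higher number from compound 1 to compound 3 (0.05 log units; within the scatter) staying within the usual scatter. Compound 3 is therefore estimated at 35000 nM, with a range from 15000 nM to 80000 nM.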

Compound 3, half-maximal inhibitory concentration: 17600 nM
Compound 3: the middle estimate sits 2.0-fold (0.30 log units) above what was measured, and the stated range covers the measured number.
By their numbers in this assay, from the lowest: compounds 3, 1 and 2 (each within the scatter of the next, the first and the last beyond it).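

In this assay, bromo in place of methyl at this place, para to a methoxycarbonyl group, gives (a 1.8-fold lower number from compound 1 to compound 3 (0.25 log units; within the scatter)), so this swap on its own does not separate the two compounds. The comparison that does separate compounds is between two bromo compounds, which differ only in where the bromo sits on the ester-bearing ring: (a 2.4-fold lower number from compound 2 to compound 3 (0.37 log units; beyond the scatter)), a modest step but the first beyond the scatter, so the location of the bromo on this ring can shift the number. No measurement is available that explains this difference.

As far as these compounds go, it remains open whether a chloro, a methoxy or an amino group at this place would give a number close to that of compound 3 or a clearly different one. Also open, from the compounds shown here alone, is how a plain hydrogen here would compare with both bromo and methyl.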